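Methylamino to Methoxy: Expected Effect on Receptor Activation

The source may hold more compounds than are shown below. What is called first, only, known or untested is meant among the compounds shown, and "the series" means these compounds.

Of the compounds shown here, three built on one shared core have been measured in a functional assay on HEK293 cells for activation of melanin-concentrating hormone receptor 1 (Homo sapiens), read by inositol phosphate accumulation; a higher number here means that more compound is needed for the effect, a lower number that less compound is needed. Compound 1 `CCCc1cc(NC)c2cc(NC(=O)/C=C/c3ccc(C(F)(F)F)cc3)ccc2n1` gives 150 nM, the highest of the three numbers. Compound 3 `CCc1cc(N)c2cc(NC(=O)/C=C/c3ccc(C(F)(F)F)cc3)ccc2n1` gives 110 nM, and compound 2 `CCCc1cc(N)c2cc(NC(=O)/C=C/c3ccc(Cl)cc3)ccc2n1` gives 96 nM; both values lie within the usual scatter of the value of compound 1, so no order among the three can be claimed. For the measured compounds named here, no pair among them differs in only one place, so no single measured step is available as a guide.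

Compound 4 `CCCc1cc(OC)c2cc(NC(=O)/C=C/c3ccc(C(F)(F)F)cc3)ccc2n1` has not yet been measured. It differs from compound 1 in one place: methoxy in place of methylamino on an aromatic carbon. Going by the values given here, none of the measured compounds carries a methoxy at this position, so nothing measured so far speaks directly to this exchange. In the absence of a comparable step, a modest increase in this assay for compound 4 is expected, though a result within the scatter would not be surprising. The step of a 1.7-fold higher number from compound 1 to compound 4 (0.22 log units; within the scatter) is what is expected. Compound 4 is estimated at 250 nM, with a range from 80 nM to 800 nM.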

Compound 4, half-maximal effective concentration: 360 nM
Compound 4: the middle estimate sits 1.4-fold (0.16 log units) below what was measured, within the range that was stated.
By their numbers in this assay, from the lowest: compounds 2, 3 and 1 (each within the scatter of the next); then compound 4.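

Methoxy in place of methylamino on this aromatic carbon, opposite the ring nitrogen, gives the first single-place step available in this assay, and that step is a 2.4-fold higher number from compound 1 to compound 4 (0.38 log units; beyond the scatter). This shows that the position is not indifferent to the exchange, although the change is modest. A hydrogen-bond donor leaves with the methylamino group, but nothing measured here shows whether that loss accounts for the step.

The compounds shown leave open how a hydroxyl, ethylamino or dimethylamino group at this position would compare with methylamino and methoxy. They also leave open whether the same exchange would give a similar step with chloro in place of trifluoromethyl, or with ethyl in place of propyl.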